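Swapping an epoxide end for a hydrazone chain

This account rests on a few compounds, and the source may have more. Where it says the series, first, only, none or still open, it means among the compounds named here.

Compound 1 `C=C[C@](C)(CCCC(C)C)CCc1ccc(O)cc1` gives > 52000 nM as a limit
Compound 2 `C=C[C@@](C)(/C=C/c1ccc(O)cc1)CCC1OC1(C)C` gives > 52000 nM as a limit

Both entries come from a functional assay on HepG2 cells (Homo sapiens) for cytotoxicity, with a stated time of 72 h (a lower number here means that less compound is needed, a higher number that more compound is needed for the effect), and neither is an exact number. Compound 2 stands only at a limit, > 52000 nM, and it has no exact value. Compound 1 shares that position, so the evidence so far is the limit of > 52000 nM in this assay, at which 2 of the 2 values shown sit.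

Compound 3 `C=C[C@@](C)(/C=C/c1ccc(O)cc1)CC/C=C(C)/C=N/N` differs from compound 2 in one place: a group of 6 heavy atoms (4 carbon, 2 nitrogen; no ring) in place of a group of 5 heavy atoms (4 carbon, 1 oxygen; one three-membered non-aromatic ring with 1 hetero atom), on a saturated chain carbon, three bonds along the chain from two double-bonded chain carbons. The 3,3-dimethyloxiran-2-yl group leaves, and a group with no ring and two nitrogens enters. Within the data shown here, no measured pair of compounds gives the size of such a change. The expected result is an at least 1.3-fold lower number from compound 2 to compound 3 (0.11 log units; that floor lies within the scatter), a modest move toward less compound needed, and another limit in this assay would be no surprise. For compound 3 the estimated value is 40000 nM, with an expected range from 15000 nM to 100000 nM.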

Compound 3, half-maximal effective concentration: > 52000 nM
Compound 3 ended at the assay's limit; the forecaster's own chance of this, stated with the estimate: 60%; middle value at least 1.3-fold (0.11 log units) away from the limit.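

In this assay compound 3 gives > 52000 nM as a limit. Among these compounds, compound 2 gives > 52000 nM as a limit too, so no step between these two compounds can be read. The compounds shown leave open whether replacing the 3,3-dimethyloxiran-2-yl group changes the amount of compound needed at all.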